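Methoxy in Place of Fluoro, Starting From an Inactive Compound

A few compounds are considered here, and "the series" means these few. Any claim that something is new, unique, unknown or untested is made for them only; others in the source may bear on it.

Compound 1, `C=C(c1ccc(F)c(F)c1)C1COC(C)(C)OO1`: > 100000 nM
Compound 2, `C=C(c1ccc(F)cc1F)C1COC(C)(C)OO1`: > 100000 nM

Both values come from a functional assay on BEAS-2B cells (Homo sapiens) for inhibition, read by MTT assay, with a stated time of 72 h; a higher number here means a weaker inhibitor, a lower number a stronger inhibitor. For compound 1 the value > 100000 nM is a limit of the assay, not a number. For compound 2 the value > 100000 nM is likewise a limit. Compound 1 therefore stands at the limit of > 100000 nM in this assay, at which 2 of the 2 values shown sit. Compound 3, `C=C(c1ccc(OC)c(F)c1)C1COC(C)(C)OO1`, differs from compound 1 by methoxy in place of fluoro on an aromatic carbon. Among the compounds with values here, no step between measured compounds is available, so the effect of such a change cannot be read from these data. With compound 1 sitting at the limit of > 100000 nM in this assay, at which 2 of the 2 values shown sit, compound 3 is expected to show no step beyond the scatter, a number no higher from compound 1 to compound 3 (the limit leaves the size open). The estimate for compound 3 is 100000 nM, within 20000 nM to 300000 nM.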

Compound 3, half-maximal inhibitory concentration: 68700 nM
For compound 3 the middle estimate is 1.5-fold (0.16 log units) above the measured one; measured number inside the range.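

With methoxy on this aromatic carbon, compound 3 is the only compound shown that gives a number in this assay, at 68700 nM. For compound 1, > 100000 nM is a limit of the assay, not a number. From the compounds shown here alone, the change therefore gives only a floor, an at least 1.4-fold lower number from compound 1 to compound 3 (0.16 log units; that floor lies within the scatter), so the true size of the step stays unknown and may be small or large.

Going by these compounds, how an amine, a hydroxyl or a longer chain such as ethoxy would behave at this position stays open.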